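Ethoxy to methoxy: one small change in the series

The source may report more compounds than this note shows. Statements on the series, on what has been measured and on what is new or still open speak of the compounds shown alone.

In an ADME assay on Vero cells (Chlorocebus sabaeus) for cytotoxicity, read by MTT assay, with a stated time of 72 h (a lower number here means that less compound is tolerated, a higher number that more compound is tolerated), compound 1 (`CCOC(=O)c1c(-c2ccc(OC)cc2)oc2ccc(OCCCCCCN3C(=O)/C(=N\OC)c4cc(F)ccc43)cc12`) stands at 16 ug/mL and compound 2 (`CCOC(=O)c1c(-c2ccccc2)oc2ccc(OCCCN3C(=O)/C(=N\OC)c4ccccc43)cc12`) at 64 ug/mL while compound 3 (`CCO/N=C1\C(=O)N(CCCCOc2ccc3oc(-c4ccc(OC)cc4)c(C(=O)OCC)c3c2)c2ccc(F)cc21`) stands at 32 ug/mL in the middle of the three numbers, within the scatter of both others. Compound 4 (`CCOC(=O)c1c(-c2ccc(OC)cc2)oc2ccc(OCCCCN3C(=O)/C(=N\OC)c4cc(F)ccc43)cc12`) differs from compound 3 through hydrogen in place of methyl on a saturated chain carbon bound to an oxygen on an unsaturated carbon as hydrogen in place of methyl on a saturated chain carbon bound to an oxygen on an unsaturated carbon, which reads ethoxy to methoxy. Among the measured compounds shown here, no measured pair isolates this change. The expected change is no change at the digits printed from compound 3 to compound 4 (within the scatter) in this assay and so none beyond the scatter, an expectation resting on compound 3 at 32 ug/mL as the only close reference. For compound 4 the estimate is 32 ug/mL with an expected range from 16 ug/mL to 64 ug/mL in this assay.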

Compound 4, half-maximal cytotoxic concentration: 32 ug/mL
For compound 4 middle estimate and measured number coincide at the digits printed, within the range that was stated.
By their numbers in this assay, from the lowest: compounds 1, 3, 4 and 2 (each within the scatter of the next, the first and the last beyond it).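

In this assay, ethoxy to methoxy gives no change at the digits printed from compound 3 to compound 4 (within the scatter). Among the compounds shown here, this is the first pair that differs in one place, and it shows that hydrogen in place of methyl at this place leaves the read-out within the scatter. No supporting measurement bears on this result.

As far as these compounds go, whether a longer chain such as propoxy, or a terminal amine on that chain, would also stay within the scatter remains open. A single step also cannot show how the same change behaves on another core.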